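Swapping Chloro for Fluoro on an Aryl Triazole

The source may hold more compounds than are shown below. What is called first, only, known or untested is meant among the compounds shown, and "the series" means these compounds.

Among the measured compounds shown here, compound 1, `CC1(C)[C@H]2CC[C@]1(C)N(Cc1cn(-c3ccc(Cl)cc3)nn1)C(=O)C2`, is one of two compounds measured in a functional assay on SGC-7901 cells (Homo sapiens) for inhibition, read by MTT assay, with a stated time of 24 h; a higher number here means a weaker inhibitor, a lower number a stronger inhibitor. In this assay, for the measured compounds named here, compound 1 gives 410 nM, the lower of the two numbers, though its only neighbour sits within the usual scatter of it. Compound 2, `CC1(C)[C@H]2CC[C@]1(C)N(Cc1cn(-c3ccccc3Br)nn1)C(=O)C2`, gives 500 nM in this assay. Going by the values given here, the single measured step, a 1.2-fold higher number from compound 1 to compound 2 (0.09 log units; within the scatter), stays within the scatter, so the two compounds cannot be ranked against each other.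

Compound 3, `CC1(C)[C@H]2CC[C@]1(C)N(Cc1cn(-c3ccc(F)cc3)nn1)C(=O)C2`, is not yet measured. It differs from compound 1 by fluoro in place of chloro on an aromatic carbon. Among the compounds with values here, no measured step exchanges one halogen for another at the same place on that ring; the only step available, from compound 1 to compound 2, changes both the halogen and where it sits, and even that leaves the number within the scatter. With nothing pointing to a shift, the expected step from compound 1 to compound 3 is a 1.2-fold higher number from compound 1 to compound 3 (0.09 log units; within the scatter), which means no movement beyond the scatter. On that basis compound 3 is estimated at 500 nM in this assay, with a range from 230 nM to 1100 nM.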

Compound 3, half-maximal inhibitory concentration: 500 nM
The estimate for compound 3 equals the measured number at the digits printed; the measured number falls inside the stated range.
By their numbers in this assay, from the lowest: compounds 1, 2 and 3 (each within the scatter of the next).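

Among the compounds shown here, compound 3 supplies the step the earlier compounds lacked, in which the halogen is exchanged while its place on the ring stays fixed: in this assay, the change from 4-chlorophenyl to 4-fluorophenyl gives a 1.2-fold higher number from compound 1 to compound 3 (0.09 log units; within the scatter). The other new step, no change at the digits printed from compound 2 to compound 3 (within the scatter), also stays within the scatter, so the three aryl groups shown, which vary in both halogen and ring position, cannot be ranked in this assay. Nothing measured here bears on what lies behind this result.

As far as these compounds go, all three compounds carry a single halogen on the phenyl ring, so it remains open whether an amine, a carboxylic acid or a methoxy group at the place para to a large group, or a plain phenyl ring with no added group, would give a number beyond the scatter of these values. The shared core and the triazole are also the same throughout, so the compounds shown say nothing about how a change in either part would affect the number in this assay.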